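A few compounds are considered here, and "the series" means these few. Any claim that something is new, unique, unknown or untested is made for them only; others in the source may bear on it.

Measured in a functional assay on MCF7 cells (Homo sapiens) for antiproliferative activity, read by MTT assay; on this read-out higher numbers stand for weaker inhibition and lower numbers for stronger inhibition:
- compound 1 `COc1ccc(-c2nc(N3CCNCC3)nc3ccccc23)c(OC)c1`: 50 ug/mL
- compound 2 `COc1cc(OC)c(-c2nc(N3CCN(C)CC3)nc3ccccc23)c(OC)c1`: 50 ug/mL

Compound 2 stands level with compound 1 at the digits available, within the scatter. Compound 3 `COc1cc(OC)c(-c2nc(N3CCNCC3)nc3ccccc23)c(OC)c1` follows from compound 2 by hydrogen in place of methyl on an amine nitrogen in a ring. Within the data shown here, no measured pair isolates this change, so the expectation rests only on these two values, and no step beyond the scatter is expected in this assay. The expected change is no change at the digits printed from compound 2 to compound 3 (within the scatter). Compound 3 is estimated at 50 ug/mL, with an expected range of 25 ug/mL to 100 ug/mL.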

Compound 3, half-maximal inhibitory concentration: 50 ug/mL
For compound 3 middle estimate and measured number coincide at the digits printed; measured number inside the range.
By their numbers in this assay, from the lowest: compounds 1, 2 and 3 (each within the scatter of the next).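

this assay shows no change at the digits printed from compound 2 to compound 3 (within the scatter) when hydrogen replaces methyl on the amine nitrogen in a ring, the first direct reading of this change, so 4-methylpiperazin-1-yl and piperazin-1-yl are not told apart here. The same assay, this assay, gives no change at the digits printed from compound 1 to compound 3 (within the scatter) when methoxy replaces hydrogen on an aromatic carbon. No measurement at hand accounts for either result.

From the compounds shown here alone, whether an acetyl group or a longer alkyl chain on that ring nitrogen would separate from these values stays open. So does the effect of an amine or a carboxylic acid on the aromatic ring.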